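A few compounds are considered here, and "the series" means these few. Any claim that something is new, unique, unknown or untested is made for them only; others in the source may bear on it.

Compound 1, `O=C(Nc1ccc(Br)cn1)c1csc(Cc2c(Cl)cccc2Cl)n1`: > 4000 nM
Compound 2, `O=C(Nc1ccc(C(F)(F)F)cc1)c1c[nH]c(Cc2c(Cl)cccc2Cl)n1`: 230 nM

In an assay on CHO cells, read by calcium flux (a higher number here means a weaker inhibitor, a lower number a stronger inhibitor), compound 1 gives only a limit, > 4000 nM, which is the limit of > 4000 nM in this assay, at which 1 of the 2 values shown sits. For the measured compounds named here, compound 2 stands alone with the only number in this assay, where compound 2 gives 230 nM. Compound 3, `Cn1cc(C(=O)Nc2ccc(C(F)(F)F)cc2)nc1Cc1c(Cl)cccc1Cl`, has not yet been measured in this assay. It differs from compound 2 by methyl in place of hydrogen on an aromatic nitrogen. Going by the values given here, no step between measured compounds is known here, so the expectation rests on compound 2 alone: a modest weakening is expected, of a 2.2-fold higher number from compound 2 to compound 3 (0.34 log units; beyond the scatter). Compound 3 is therefore estimated at 500 nM, with a range from 150 nM to 2500 nM.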

Compound 3, half-maximal inhibitory concentration: 1010 nM
Compound 3: the middle estimate sits 2.0-fold (0.31 log units) below what was measured, within the range that was stated.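

Placing methyl in place of hydrogen on the aromatic nitrogen gives a 4.4-fold higher number from compound 2 to compound 3 (0.64 log units; beyond the scatter) in this assay. For the compounds shown here, this is the first reading at this position: the change weakens the inhibitor modestly, yet compound 3 still gives a measured number rather than a limit. Nothing shown accounts for the size of this step.

Going by these compounds, whether an ethyl group or a longer chain ending in an amine on this nitrogen would weaken the inhibitor further remains open. So does whether the step would be the same size with another group in place of the trifluoromethyl.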